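From 4-hydroxypiperidin-1-yl to 3-hydroxypiperidin-1-yl

The source may report more compounds than this note shows. Statements on the series, on what has been measured and on what is new or still open speak of the compounds shown alone.

Compound 1 `O=C(NCc1ccc(S(=O)(=O)C2CCC(F)(F)CC2)cc1)N1Cc2ccncc2C1`: 13 nM
Compound 2 `O=C(NCc1ccc(S(=O)(=O)N2CCC(O)CC2)cc1)N1Cc2ccncc2C1`: 98 nM

Both values come from a functional assay on A2780 cells (Homo sapiens) for cytotoxicity, read by sulforhodamine B assay, with a stated time of 72 h; on this read-out higher numbers stand for weaker inhibition and lower numbers for stronger inhibition. Compound 2 has the higher number of the pair, which makes it the weaker inhibitor of the two. The next compound to be measured is compound 3 `O=C(NCc1ccc(S(=O)(=O)N2CCC[C@H](O)C2)cc1)N1Cc2ccncc2C1`, and it differs from compound 2 in one place, on a sulfonyl sulfur whose other neighbour is an aromatic carbon: 3-hydroxypiperidin-1-yl in place of 4-hydroxypiperidin-1-yl on a sulfonyl sulfur. It has 3-hydroxypiperidin-1-yl in place of 4-hydroxypiperidin-1-yl, so the two compounds have the same atoms, joined differently.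

Among the compounds with values here, only one measured step exists, a 7.5-fold higher number from compound 1 to compound 2 (0.88 log units; beyond the scatter). It exchanged 4,4-difluorocyclohexyl for 4-hydroxypiperidin-1-yl, a different kind of change, so it bears only loosely on this one. Within the data shown here, no measured pair shows what relocating the hydroxyl does. A step beyond the scatter in this assay is therefore not expected, and no direction can be favoured, though the uncertainty remains wide. The estimated step is a 1.0-fold higher number from compound 2 to compound 3 (0.01 log units; within the scatter). The expected value for compound 3 is 100 nM, with an estimated range of 35 nM to 290 nM.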

Compound 3, half-maximal inhibitory concentration: 150 nM
Compound 3: the middle estimate sits 1.5-fold (0.18 log units) below what was measured, and the stated range covers the measured number.
By their numbers in this assay, from the lowest: compound 1; then compounds 2 and 3 (each within the scatter of the next).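

Moving the hydroxyl from 4-hydroxypiperidin-1-yl to 3-hydroxypiperidin-1-yl on the sulfonyl sulfur gives a small step in this assay (a 1.5-fold higher number from compound 2 to compound 3 (0.18 log units; within the scatter)), so the assay cannot tell these two placements apart. The larger gap lies elsewhere: the change from 4,4-difluorocyclohexyl gives a clear step (a 12-fold higher number from compound 1 to compound 3 (1.06 log units; beyond the scatter)), so compound 2 and compound 3 both sit well above compound 1, and that holds for either hydroxyl placement. Nothing available explains why exchanging the 4,4-difluorocyclohexyl group matters so much more here than where the hydroxyl sits.

The compounds shown leave open whether the mirror-image form of 3-hydroxypiperidin-1-yl would read like compound 3, since its one defined stereocentre is shown in a single arrangement. They also leave open whether the hydroxyl itself contributes to the gap from compound 1, a question that a plain piperidin-1-yl group, a methoxy group or an amine in the hydroxyl's place could help to answer.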